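The source may hold more compounds than are shown below. What is called first, only, known or untested is meant among the compounds shown, and "the series" means these compounds.

Measured compounds:
compound 1 `CNC(=O)/C=C/c1ccncc1-c1ccc2cc[nH]c2c1` — 10400 nM
compound 2 `O=C(O)/C=C/c1ccncc1-c1ccc2cc[nH]c2c1` — > 30000 nM
compound 3 `CNC(=O)/C=C/c1ccncc1-c1ccc2[nH]ccc2c1` — > 30000 nM

In a functional assay on HCT-116 cells (Homo sapiens) for inhibition, read by MTT assay, with a stated time of 72 h (on this read-out higher numbers stand for weaker inhibition of growth and lower numbers for stronger inhibition of growth), compound 1 gives 10400 nM. Compound 2 reaches only a limit of this assay, > 30000 nM. The change between them is hydroxy in place of methylamino on a carbonyl carbon, and it gives an at least 2.8-fold higher number from compound 1 to compound 2 (0.46 log units; beyond the scatter); that the step is only a lower bound rests on (the limit of > 30000 nM in this assay, at which 2 of the 3 values shown sit).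

Compound 3 likewise reaches only a limit of this assay, > 30000 nM. The difference between the core of compound 3 and the core of compound 1 is not broken down here.

Compound 4 `O=C(O)/C=C/c1ccncc1-c1ccc2[nH]ccc2c1` is not yet measured. For the measured compounds named here, it differs from compound 3 by hydroxy in place of methylamino on a carbonyl carbon, the same change as the one from compound 1 to compound 2. Since compound 3 already sits at > 30000 nM and the earlier step was an at least 2.8-fold higher number from compound 1 to compound 2 (0.46 log units; beyond the scatter), compound 4 is expected to stay at the limit, an expected step that the limit leaves unreadable from compound 3 to compound 4. Compound 4 is therefore estimated at 60000 nM, between 30000 nM and 150000 nM.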

Compound 4, concentration for 50% growth inhibition: > 30000 nM
Compound 4 ended at the assay's limit (the forecaster's own chance of this, stated with the estimate: 85%); the middle value does not contradict the limit.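

Compound 3 and compound 4 both sit at a limit of this assay, so no step can be read between them: the limit of > 30000 nM in this assay, at which 3 of the 4 values shown sit.

The compounds shown leave open how methylcarbamoyl and carboxy compare on the core of compound 3.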